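A few compounds are considered here, and "the series" means these few. Any claim that something is new, unique, unknown or untested is made for them only; others in the source may bear on it.

Three compounds that share one core, and differ only in the group on an aromatic nitrogen, have been tested in a functional assay on DU-145 cells (Homo sapiens) for cytotoxicity, read by MTT assay, with a stated time of 48 h; a higher number here means a weaker inhibitor, a lower number a stronger inhibitor. Compound 1 (`C=C1CCC[C@]2(C)CCC(c3cn(-c4cccc([N+](=O)[O-])c4)nn3)=CC[C@@]12C`) gives 62500 nM, compound 2 (`C=C1CCC[C@]2(C)CCC(c3cn(-c4ccc(I)cc4)nn3)=CC[C@@]12C`) gives 145000 nM, and compound 3 (`C=C1CCC[C@]2(C)CCC(c3cn(-c4ccccc4C(C)=O)nn3)=CC[C@@]12C`) gives 48500 nM. The position of compound 3 follows from two steps: there is a 1.3-fold lower number from compound 1 to compound 3 (0.11 log units; within the scatter), and there is a 3.0-fold lower number from compound 2 to compound 3 (0.48 log units; beyond the scatter). It therefore lies within the scatter of one neighbour and clearly under the other.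

Compound 4 (`C=C1CCC[C@]2(C)CCC(c3cn(-c4cccc(OC)c4)nn3)=CC[C@@]12C`) has 3-methoxyphenyl in place of 2-acetylphenyl on an aromatic nitrogen. This exact swap has not been measured, but all three known steps change the group at this same place. They range from within the scatter to modest. The closest in kind is the exchange of 3-nitrophenyl for 2-acetylphenyl, which is a 1.3-fold lower number from compound 1 to compound 3 (0.11 log units; within the scatter). The largest is the one that involves the 4-iodophenyl group of compound 2, at 145000 nM. No step beyond the scatter is expected, and the estimated shift in this assay is a 1.3-fold higher number from compound 3 to compound 4 (0.13 log units; within the scatter). For compound 4 the expected value is 65000 nM, with an estimated range of 30000 nM to 140000 nM.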

Compound 4, half-maximal inhibitory concentration: 38900 nM
For compound 4 the middle estimate is 1.7-fold (0.22 log units) above the measured one; the measured number falls inside the stated range.
By their numbers in this assay, from the lowest: compounds 4, 3 and 1 (each within the scatter of the next); then compound 2.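

In this assay, going by these compounds alone, 3-methoxyphenyl joins 2-acetylphenyl and 3-nitrophenyl as a third group on the aromatic nitrogen that cannot be told apart from its neighbours (a 1.2-fold lower number from compound 3 to compound 4 (0.10 log units; within the scatter)), and the exchange of methoxy for nitro on an aromatic carbon, the first change here confined to the group carried by the phenyl ring, also stays inside the scatter (a 1.6-fold lower number from compound 1 to compound 4 (0.21 log units; within the scatter)). Compound 2 therefore stands alone among the four, since its 4-iodophenyl group now has a step beyond the scatter to each of the other compounds, the largest being (a 3.7-fold lower number from compound 2 to compound 4 (0.57 log units; beyond the scatter)), although that step is still modest. The numbers alone do not explain this separation, and no measurement bearing on it is available here.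

The compounds shown leave open whether the gap at compound 2 belongs to the iodine itself or to where it sits on the phenyl ring. They also leave open how the shared core would read with an amine or a carboxylic acid on that ring, or with a longer alkyl chain on the aromatic nitrogen in place of the phenyl ring.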